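Pyridyl Switch on the Cyclohexyl Amide Core

The source may hold more compounds than are shown below. What is called first, only, known or untested is meant among the compounds shown, and "the series" means these compounds.

Compound 1 `CC(C)N1CCc2nc(C#Cc3ccccn3)ccc2C1=O` and compound 3 `O=C1c2ccc(C#Cc3ccccn3)nc2CCN1C1CCCCC1` share a core and differ only at the amide-type nitrogen in a ring: cyclohexyl in place of isopropyl on an amide-type nitrogen in a ring. In an assay on HEK293 cells for displacement of a labelled ligand from metabotropic glutamate receptor 5 (Homo sapiens), with a stated time of 2 h (on this read-out higher numbers stand for weaker inhibition and lower numbers for stronger inhibition), compound 1 gives 2740 nM, and compound 3 gives 2240 nM, so that a 1.2-fold lower number from compound 1 to compound 3 (0.09 log units; within the scatter). Compound 2 `CC(C)N1CCc2nc(C#Cc3cccnc3)ccc2C1=O` carries the change pyridin-3-yl in place of pyridin-2-yl on a triple-bonded carbon and in this assay gives 19600 nM; here a 7.2-fold higher number from compound 1 to compound 2 (0.85 log units; beyond the scatter). Compound 4 `O=C1c2ccc(C#Cc3cccnc3)nc2CCN1C1CCCCC1` has not yet been measured. It carries the same change relative to compound 3, (pyridin-3-yl in place of pyridin-2-yl on a triple-bonded carbon), at a place described in the same words. Because the same change gave a 7.2-fold higher number from compound 1 to compound 2 (0.85 log units; beyond the scatter), a step of about a 7.1-fold higher number from compound 3 to compound 4 (0.85 log units; beyond the scatter) is expected in this assay. Compound 4 is accordingly estimated at 16000 nM, with a plausible range from 6000 nM to 40000 nM.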

Compound 4, inhibition constant: 15600 nM
For compound 4 the middle estimate is 1.0-fold (0.01 log units) above the measured one; the range from low to high includes it.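

In this assay, pyridin-3-yl in place of pyridin-2-yl with cyclohexyl on the ring nitrogen gives a 7.0-fold higher number from compound 3 to compound 4 (0.84 log units; beyond the scatter), and this step matches the one seen with isopropyl there: the same change on two cores in this assay, a 7.2-fold higher number (0.85 log units; beyond the scatter) from compound 1 to compound 2 and a 7.0-fold higher number (0.84 log units; beyond the scatter) from compound 3 to compound 4, 1.0-fold (0.01 log units) apart, within the scatter of two such steps. Cyclohexyl in place of isopropyl with pyridin-3-yl gives a 1.3-fold lower number from compound 2 to compound 4 (0.10 log units; within the scatter), and this step also reads the same with either pyridine: the same change on two cores in this assay, a 1.2-fold lower number (0.09 log units; within the scatter) from compound 1 to compound 3 and a 1.3-fold lower number (0.10 log units; within the scatter) from compound 2 to compound 4, 1.0-fold (0.01 log units) apart, within the scatter of two such steps. The four compounds show that both changes carry over between these two cores in this one assay, but they do not show that the steps would hold on any other core, nor why they take the size they do.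

The compounds shown leave open how a pyridin-4-yl or a phenyl group on the triple-bonded carbon would read. They also leave open whether a methyl group or a chain bearing an amine on the ring nitrogen would follow the same steps.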